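Aryl exchange on the shared core: expectation for compound 3

The compounds below may be only part of what the source reports. "The series", "measured", "known", "first", "only" and "open" are said of these compounds alone.

Measured compounds:
compound 1, `OCc1cccc(C2=NC(c3ccc(F)cc3)(c3ccc(F)cc3)CN2)c1`, giving 59 nM in an assay on LM cells for displacement of a labelled ligand from Neuropeptide Y receptor type 5 (Homo sapiens); a higher number here means a weaker inhibitor, a lower number a stronger inhibitor
compound 2, `Fc1ccc(C2(c3ccc(F)cc3)CNC(c3cncnc3)=N2)cc1`, giving 47 nM in this assay

Compound 2 stands at the lowest of the two numbers, and its nearest neighbour is compound 1: the step of a 1.3-fold lower number from compound 1 to compound 2 (0.10 log units; within the scatter) is within the scatter, so the two compounds cannot be told apart on these data.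

Compound 3, `N#Cc1cc(C2=NC(c3ccc(F)cc3)(c3ccc(F)cc3)CN2)ccn1`, has not yet been measured. It differs from compound 2 in one place: 2-cyanopyridin-4-yl in place of pyrimidin-5-yl on a carbon with a double bond to nitrogen. Among the measured compounds shown here, the only measured step that bears on this change is the earlier aryl exchange at the same carbon, a 1.3-fold lower number from compound 1 to compound 2 (0.10 log units; within the scatter), which was within the scatter. One such step is a thin base, and the new group, 2-cyanopyridin-4-yl, has not appeared among the measured compounds, so nothing here points to a step beyond the scatter in either direction in this assay.

Compound 3 is therefore expected to give 45 nM, with a range from 15 nM to 140 nM, which means the step of a 1.0-fold lower number from compound 2 to compound 3 (0.02 log units; within the scatter) is estimated to stay within the scatter.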

Compound 3, half-maximal inhibitory concentration: 4.8 nM
The estimate for compound 3 lay 9.4-fold (0.97 log units) above the measured number; measured number below the stated range.
By their numbers in this assay, from the lowest: compound 3; then compounds 2 and 1 (each within the scatter of the next).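

In this assay, the exchange of 2-cyanopyridin-4-yl for pyrimidin-5-yl gives a 9.8-fold lower number from compound 2 to compound 3 (0.99 log units; beyond the scatter) and the exchange for 3-(hydroxymethyl)phenyl gives a 12-fold lower number from compound 1 to compound 3 (1.09 log units; beyond the scatter) at the same carbon, so this group separates itself from both earlier ones by more than the scatter. The earlier exchange at this place, a 1.3-fold lower number from compound 1 to compound 2 (0.10 log units; within the scatter) on its own, had left open whether the carbon between two ring nitrogen atoms responds to its aryl group at all, and compound 3 shows that it does in this assay. No measurement is at hand that would account for the size of these steps.

The entering group differs from pyrimidin-5-yl both in its nitrile and in its ring, which holds 1 hetero atom rather than 2, and the compounds shown do not separate these two features. On these data alone, it remains open whether plain pyridin-4-yl would keep the low number of compound 3, or whether a carboxamide or a chlorine in place of the nitrile would do the same, and all three compounds carry the same two 4-fluorophenyl groups, so the result says nothing about how far it holds with other groups there.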